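Removing the Aryl Group from a Thienopyrrole Amide

The compounds below may be only part of what the source reports. "The series", "measured", "known", "first", "only" and "open" are said of these compounds alone.

Measured compounds:
- compound 1, `CCCNC(=O)C1CCN(C(=O)c2cc3sc(-c4ccccc4F)cc3n2Cc2ccc(OC)cc2)CC1`: 0.592 h
- compound 2, `CCCNC(=O)[C@@H]1CCCN1C(=O)c1cc2sc(Br)cc2n1Cc1ccc(OC)cc1`: 0.303 h

Both compounds were tested in an ADME assay on microsomes from liver (Homo sapiens) for metabolic stability; a higher number here means that the compound lasts longer, a lower number that the compound disappears faster. Compound 1 gives 0.592 h, the higher of the two numbers. Compound 2 gives 0.303 h, and the gap between the two lies within the scatter, so the two values cannot be told apart with confidence. Within the data shown here, compound 2 also differs from compound 1 in more than one place, so no single structural step links them.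

Compound 3, `CCCNC(=O)C1CCN(C(=O)c2cc3sccc3n2Cc2ccc(OC)cc2)CC1`, has not yet been measured. It differs from compound 1 in one place: hydrogen in place of 2-fluorophenyl on an aromatic carbon. Among the measured compounds shown here, no comparable step between measured compounds exists to guide the expectation, so the direction is uncertain. The step of a 1.3-fold lower number from compound 1 to compound 3 (0.12 log units; within the scatter) is expected to be small and to stay within the scatter. For compound 3 a half-life of 0.45 h is estimated, with a range from 0.2 h to 1 h.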

Compound 3, half-life: 0.177 h
Compound 3: middle estimate off by 2.5-fold (0.41 log units), on the high side; the measured number lies below the stated range.
By their numbers in this assay, from the lowest: compounds 3, 2 and 1 (each within the scatter of the next, the first and the last beyond it).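

In this assay, replacing the 2-fluorophenyl group with hydrogen on the aromatic carbon next to the ring sulfur gives a 3.3-fold lower number from compound 1 to compound 3 (0.52 log units; beyond the scatter). Among these compounds, this is the first single-place comparison, and it shows that the half-life responds to what sits at this position. With everything else in the molecule unchanged, the compound carrying the 2-fluorophenyl group has the higher number, yet no measurement shown gives a reason for the step.

Among the compounds shown here, with only two groups compared at this position, it remains open whether the whole ring or its fluorine accounts for the difference, and a plain phenyl or a methyl group would help separate these. Compound 2 carries bromine here but also differs elsewhere, so it cannot settle how a single atom at this position behaves.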